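The compounds below may be only part of what the source reports. "The series", "measured", "known", "first", "only" and "open" are said of these compounds alone.

Working notes on the series. Compound 1 `CC(C)=CCC/C(C)=C/CC/C(C)=C/CC[C@]1(C)CCc2c(C)c(OC(=O)Nc3ccccc3)c(C)c(C)c2O1` is the reference point. In a functional assay on MDA-MB-231 cells (Homo sapiens) for antiproliferative activity, read by MTT assay, with a stated time of 96 h (on this read-out higher numbers stand for weaker inhibition and lower numbers for stronger inhibition), compound 1 gives > 10000 nM, which is a limit of the assay and not a number. Compound 2 `CC(C)=CCC/C(C)=C/CC/C(C)=C/CC[C@]1(C)CCc2cc(OC(=O)NS(=O)(=O)c3ccc(Cl)cc3)cc(C)c2O1` differs in the core substitution as well as in the group on the nitrogen. In this assay compound 2 gives > 10000 nM, again a limit rather than a number. Compound 3 `CC(C)=CCC/C(C)=C/CC/C(C)=C/CC[C@]1(C)CCc2cc(OC(=O)NC(=O)Oc3ccccc3)cc(C)c2O1` carries no result in this assay: "not determined" (no result reported). For the measured compounds named here, compound 1 therefore stands only at a limit; of the two further entries one is likewise a limit and one has no number, so no step between measured compounds can be computed, and the limit of > 10000 nM in this assay, at which 2 of the 3 values shown sit, is the single fixed point.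

Compound 4 `CC(C)=CCC/C(C)=C/CC/C(C)=C/CC[C@]1(C)CCc2c(C)c(OC(=O)NS(=O)(=O)c3ccc(C)cc3)c(C)c(C)c2O1` is the next entry for this assay. It differs from compound 1 by (4-methylphenyl)sulfonyl in place of phenyl on an amide-type nitrogen. Going by the values given here, with compound 1 at a limit, no measured step gives a direction; compound 2, the other entry with a sulfonyl group on the nitrogen, also shows only a limit. The step from compound 1 to compound 4 is expected to be a step that the limit leaves unreadable from compound 1 to compound 4, that is, none beyond the scatter. Compound 4 is thus estimated at 15000 nM, within a range from 5000 nM to 50000 nM, most likely reported again as a limit.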

Compound 4, half-maximal inhibitory concentration: > 10000 nM
Compound 4: a limit, no number; the forecaster's own chance of this, stated with the estimate: 80%; the middle value lies beyond the limit too.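

Compound 1 and compound 4 both stand at a limit and not at a number, so no step between them can be read: the limit of > 10000 nM in this assay, at which 3 of the 4 values shown sit.

The compounds shown leave open whether any change on the amide-type nitrogen or in the core gives a readable value in this assay.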